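Swapping a five-membered ring at the chloro-bearing ring

This account rests on a few compounds, and the source may have more. Where it says the series, first, only, none or still open, it means among the compounds named here.

Three compounds share one core and differ only in the group attached to the chlorinated benzene ring. In an assay on isolated protein for inhibition of ubiquitin carboxyl-terminal hydrolase 7 (Homo sapiens), with stated times of 30 min and 2 h (on this read-out lower numbers stand for stronger inhibition and higher numbers for weaker inhibition), compound 1 `Cn1nc2c(=O)n(CC3(O)CCN(Cc4ccc(-c5ccncc5)cc4Cl)CC3)cnc2c1-c1ccc(CN)cc1` gives 257 nM, compound 2 `Cn1nc2c(=O)n(CC3(O)CCN(Cc4ccc(C5=CCCC5)cc4Cl)CC3)cnc2c1-c1ccc(CN)cc1` gives 76.9 nM, and compound 3 `Cn1nc2c(=O)n(CC3(O)CCN(Cc4ccc(-c5ccsc5)cc4Cl)CC3)cnc2c1-c1ccc(CN)cc1` gives 59.5 nM. Compound 3 has the lowest number of the three, yet a 1.3-fold lower number from compound 2 to compound 3 (0.11 log units; within the scatter), so compound 2 and compound 3 cannot be told apart; only a 4.3-fold lower number from compound 1 to compound 3 (0.64 log units; beyond the scatter) marks a real difference. Compound 4 `Cn1nc2c(=O)n(CC3(O)CCN(Cc4ccc(-c5ncco5)cc4Cl)CC3)cnc2c1-c1ccc(CN)cc1` differs from compound 3 as follows: 1,3-oxazol-2-yl in place of thiophen-3-yl on an aromatic carbon. The step from compound 1 to compound 3 shows that a nitrogen-bearing six-membered ring gave a higher number than the thiophene, while the cyclopentenyl step (a 3.3-fold lower number from compound 1 to compound 2 (0.52 log units; beyond the scatter)) points the same way. For compound 4 a step of a 1.6-fold higher number from compound 3 to compound 4 (0.20 log units; within the scatter) is expected, so compound 4 is estimated at 95 nM with a range of 40 nM to 250 nM.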

Compound 4, half-maximal inhibitory concentration: 1120 nM
Beside the measured number, compound 4's estimate is 12-fold (1.07 log units) below it, outside the stated range (above it).
By their numbers in this assay, from the lowest: compounds 3 and 2 (each within the scatter of the next); then compound 1; then compound 4.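

In this assay putting 1,3-oxazol-2-yl in place of thiophen-3-yl gives a 19-fold higher number from compound 3 to compound 4 (1.27 log units; beyond the scatter) even though both are five-membered aromatic rings of 5 heavy atoms, so ring size alone does not settle the outcome at this position. Compound 4 also compares poorly with the other two, with a 15-fold higher number from compound 2 to compound 4 (1.16 log units; beyond the scatter) and a 4.4-fold higher number from compound 1 to compound 4 (0.64 log units; beyond the scatter) alike, which places it last of the four, behind even the pyridin-4-yl compound. Nothing measured here accounts for this drop.

Going by these compounds, whether the ring nitrogen, the ring oxygen or their arrangement matters stays open. A 1,3-thiazol-2-yl or furan-3-yl group in the same place could help separate these possibilities.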